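Series notes: amide-chain variation on a shared core

The source may hold more compounds than are shown below. What is called first, only, known or untested is meant among the compounds shown, and "the series" means these compounds.

Compound 1 `COc1ccc(-c2cc(NC(=O)CCC(=O)NCC(=O)NC(C)(C)C)nc(-c3ccc(OC)cc3)n2)cc1`, compound 2 `COc1ccc(-c2cc(NC(=O)CCC(=O)NCC(=O)NCc3ccccc3)nc(-c3ccc(OC)cc3)n2)cc1` and compound 3 `COc1ccc(-c2cc(NC(=O)COCC(=O)NCC(=O)NC3CCCCC3)nc(-c3ccc(OC)cc3)n2)cc1` share one core and differ in the chain attached to its amide. In an assay on HeLa cells for displacement of a labelled ligand from adenosine receptor A3 (Homo sapiens), read by fluorescence polarization, with a stated time of 30 min (on this read-out higher numbers stand for weaker inhibition and lower numbers for stronger inhibition), compound 1 gives 36700 nM, compound 2 gives 50800 nM and compound 3 gives 21400 nM. Compound 3 has the lowest number of the three; its gap to compound 1 is within the scatter, its gap to compound 2 beyond it. Among the compounds with values here, the only single-place step measured, a 1.4-fold higher number from compound 1 to compound 2 (0.14 log units; within the scatter), lies within the scatter. Compound 1 and compound 3 differ in more than one place, so their values can only be set side by side.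

Compound 4 `COc1ccc(-c2cc(NC(=O)COCC(=O)N(C)CC(=O)NC(C)(C)C)nc(-c3ccc(OC)cc3)n2)cc1` arises from compound 3 by methyl(((tert-butyl)carbamoyl)methyl)amino in place of ((cyclohexylcarbamoyl)methyl)amino on a carbonyl carbon. Within the data shown here, no measured step covers a methyl on that nitrogen; the tert-butyl end appears only in compound 1, whose value is not separated from compound 3 beyond the scatter. The expected step in this assay is therefore a 1.4-fold higher number from compound 3 to compound 4 (0.15 log units; within the scatter), no clear direction beyond the scatter. For compound 4 the estimate is 30000 nM, expected between 10000 nM and 90000 nM.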

Compound 4, inhibition constant: 19400 nM
Compound 4: middle estimate off by 1.5-fold (0.19 log units), on the high side, within the range that was stated.
By their numbers in this assay, from the lowest: compounds 4, 3, 1 and 2 (each within the scatter of the next, the first and the last beyond it).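

In this assay, methyl(((tert-butyl)carbamoyl)methyl)amino in place of ((cyclohexylcarbamoyl)methyl)amino on a carbonyl carbon gives a 1.1-fold lower number from compound 3 to compound 4 (0.04 log units; within the scatter), so this exchange does not separate the two compounds. The step removes the six-membered non-aromatic ring and one hydrogen-bond donor together, a larger exchange than the earlier benzyl for tert-butyl step, and it also stays within the scatter. Nothing available bears on why the number holds here.

The two parts of the exchange remain unresolved: the methyl on the nitrogen and the tert-butyl end are not read separately, and either could offset the other. Also open, from the compounds shown here alone, is whether a group of another kind on this chain, such as a primary amine or a carboxylic acid, would give a step beyond the scatter.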